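This account rests on a few compounds, and the source may have more. Where it says the series, first, only, none or still open, it means among the compounds named here.

Among the measured compounds shown here, compound 2 `O=C(/N=C(/NC(=O)c1ccno1)[Se]Cc1ccccc1)c1ccno1`, the benzylseleno member of the series, gives 6820 nM in a functional assay on HT-29 cells (Homo sapiens) for cytotoxicity, read by MTT assay, with a stated time of 72 h (on this read-out higher numbers stand for weaker inhibition of growth and lower numbers for stronger inhibition of growth), the only numerical value among the two measured compounds. Compound 1 `CS/C(=N\C(=O)c1ccno1)NC(=O)c1ccno1`, the methylthio analogue, reaches only the assay limit in this assay, > 100000 nM. For the measured compounds named here, the sole measured step, an at least 14-fold lower number from compound 1 to compound 2 (1.16 log units; beyond the scatter), is a large gain, though it rests on (the limit of > 100000 nM in this assay, at which 1 of the 2 values shown sits). Compound 3 `C[Se]/C(=N\C(=O)c1ccno1)NC(=O)c1ccno1` differs from compound 2 by hydrogen in place of phenyl on a saturated chain carbon bound to a selenium atom. Going by the values given here, no measured step isolates this benzyl-to-methyl cut, and the only small-group analogue sits at the limit, so the change is taken as unfavourable. Compound 3 is expected weaker, a 5.9-fold higher number from compound 2 to compound 3 (0.77 log units; beyond the scatter). Compound 3 is estimated at 40000 nM, between 10000 nM and 200000 nM.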

Compound 3, concentration for 50% growth inhibition: 0.79 nM
Compound 3: middle estimate off by 51000-fold (4.70 log units), on the high side; measured number below the stated range.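

In this assay, hydrogen in place of phenyl on a saturated chain carbon bound to a selenium atom is a large gain rather than a loss, with an 8600-fold lower number from compound 2 to compound 3 (3.94 log units; beyond the scatter). A methyl group is thus no handicap in itself: selenium in place of sulfur, with methyl kept, gives an at least 120000-fold lower number from compound 1 to compound 3 (5.10 log units; beyond the scatter). The value of compound 1 is a limit of the assay, so this step is only a bound: the limit of > 100000 nM in this assay, at which 1 of the 3 values shown sits.

Open, on these data alone, is whether an ethyl group or a longer chain on selenium keeps this level. Also open, as far as these compounds go, is how a benzylthio group compares with the benzylseleno group.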